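The source may report more compounds than this note shows. Statements on the series, on what has been measured and on what is new or still open speak of the compounds shown alone.

Values measured in a functional assay on Jurkat cells (Homo sapiens); on this read-out lower numbers stand for stronger inhibition and higher numbers for weaker inhibition:
- compound 1 `C[C@H](NC(=O)C(=O)NCC1CCCCC1)C(=O)N[C@@H](CC(=O)O)C(=O)COc1c(F)c(F)cc(F)c1F`: 19 nM
- compound 2 `C[C@H](NC(=O)C(=O)Nc1cccnc1N(C)C)C(=O)N[C@@H](CC(=O)O)C(=O)COc1c(F)c(F)cc(F)c1F`: 27 nM
- compound 3 `C[C@H](NC(=O)C(=O)NCc1ccccc1F)C(=O)N[C@@H](CC(=O)O)C(=O)COc1c(F)c(F)cc(F)c1F`: 207 nM

Compound 3, at 207 nM, has the highest number of the three, which makes it the weakest inhibitor so far. Compound 4 `C[C@H](NC(=O)C(=O)NCc1ccc(F)cc1)C(=O)N[C@@H](CC(=O)O)C(=O)COc1c(F)c(F)cc(F)c1F` differs from it in one place only, where 2-fluorobenzyl becomes 4-fluorobenzyl: 4-fluorophenyl in place of 2-fluorophenyl on a saturated chain carbon bound to an amide-type nitrogen. The change is 4-fluorophenyl in place of 2-fluorophenyl, on a saturated chain carbon bound to an amide-type nitrogen.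

Among the measured compounds shown here, no measured step makes this exact change. The nearest evidence comes from swaps of the whole group on the amide-type nitrogen. There is an 11-fold higher number from compound 1 to compound 3 (1.04 log units; beyond the scatter), and there is a 7.7-fold higher number from compound 2 to compound 3 (0.88 log units; beyond the scatter), while a 1.4-fold higher number from compound 1 to compound 2 (0.15 log units; within the scatter). These steps show that the number in this assay can move a long way when that group is replaced. They do not show what happens when only the fluorine changes place, and the data offer no firm direction for that.

A small step is therefore expected, quite possibly none beyond the scatter. The estimate is a 1.2-fold lower number from compound 3 to compound 4 (0.09 log units; within the scatter). For compound 4 the expected value is 170 nM, with an estimated range of 60 nM to 480 nM.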

Compound 4, half-maximal inhibitory concentration: 197 nM
The estimate for compound 4 lay 1.2-fold (0.06 log units) below the measured number, within the range that was stated.
By their numbers in this assay, from the lowest: compounds 1 and 2 (each within the scatter of the next); then compounds 4 and 3 (each within the scatter of the next).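

In this assay, moving the fluorine from 2-fluorobenzyl to 4-fluorobenzyl gives a 1.1-fold lower number from compound 3 to compound 4 (0.02 log units; within the scatter) and so leaves the two compounds indistinguishable; at this position on the amide-type nitrogen, the place of the fluorine on the ring has no effect that this read-out can resolve. The larger gap to the other two groups also holds for the new compound, with a 7.3-fold higher number from compound 2 to compound 4 (0.86 log units; beyond the scatter) and a 10-fold higher number from compound 1 to compound 4 (1.02 log units; beyond the scatter) on this read-out, so it is not confined to the 2-fluorobenzyl group of compound 3. No measurement shown here offers an explanation for either result.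

The compounds shown leave open whether a plain benzyl group with no fluorine, or a benzyl group carrying a methoxy group or an amine, would give a number close to those of compound 3 and compound 4. They also leave open whether a longer chain carrying the cyclohexyl ring, in place of the cyclohexylmethyl group of compound 1, would keep that compound's number.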